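Phenyl for pyridin-4-yl: cytotoxicity outlook for compound 4

The source may report more compounds than this note shows. Statements on the series, on what has been measured and on what is new or still open speak of the compounds shown alone.

Compound 3 `COc1cc(NC(C)CCCNC(=O)NCc2ccncc2)c2ncccc2c1` gives 100000 nM in an ADME assay on HEL cells (Homo sapiens) for cytotoxicity (a higher number here means that more compound is tolerated, a lower number that less compound is tolerated), and stands level with compound 1 `COc1cc(NC(C)CCCNC(=O)NCC2CCCCC2)c2ncccc2c1` at the digits printed, compound 1 giving 100000 nM in this assay. Compound 2 `CCN(CC)C(=O)NCCCC(C)Nc1cc(OC)cc2cccnc12` gives only a limit of the assay, > 100000 nM in this assay. Compound 4 `COc1cc(NC(C)CCCNC(=O)NCc2ccccc2)c2ncccc2c1` is not yet measured; it differs from compound 3 as phenyl in place of pyridin-4-yl on a saturated chain carbon bound to an amide-type nitrogen. The step that bears most directly on it, at the same place on the chain, is no change at the digits printed from compound 1 to compound 3 (within the scatter), within the scatter. The other two steps, a number no lower from compound 1 to compound 2 (the limit leaves the size open) and a number no higher from compound 2 to compound 3 (the limit leaves the size open), run into the limit of > 100000 nM in this assay, at which 1 of the 3 values shown sits, and leave their size open. The expected step is therefore no change at the digits printed from compound 3 to compound 4 (within the scatter), none beyond the scatter. Compound 4 is estimated at 100000 nM, with a range of 50000 nM to 100000 nM in this assay.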

Compound 4, minimum cytotoxic concentration: 100000 nM
Compound 4: the middle estimate sits on the measured number at the digits printed, and the stated range covers the measured number.
By their numbers in this assay, from the lowest: compounds 1, 3 and 4 (each within the scatter of the next).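

In this assay, phenyl in place of pyridin-4-yl on a saturated chain carbon bound to an amide-type nitrogen gives no change at the digits printed from compound 3 to compound 4 (within the scatter), so the hydrogen-bond acceptor that leaves with pyridin-4-yl makes no readable difference at this place. An aromatic carbon ring also reads the same as a saturated one: no change at the digits printed from compound 1 to compound 4 (within the scatter). Compound 2 gives only a limit of the assay, > 100000 nM. Benzylamino in place of diethylamino on a carbonyl carbon gives a number no higher from compound 2 to compound 4 (the limit leaves the size open), and the size of this step cannot be read.

Three different rings at this place give no spread to work from. As far as these compounds go, whether a carboxylic acid or an amine on the phenyl, or a longer chain at this place, would move the number remains open.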